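Methoxy step on two cores: one measured, one pending

A few compounds are considered here, and "the series" means these few. Any claim that something is new, unique, unknown or untested is made for them only; others in the source may bear on it.

Measured in a functional assay on UACC-62 cells (Homo sapiens) for inhibition, read by sulforhodamine B assay, with a stated time of 48 h; on this read-out lower numbers stand for stronger inhibition of growth and higher numbers for weaker inhibition of growth:
compound 1, `C=C(C)[C@@H]1CC=C(Cn2cc(COc3cccc(C4NC(=O)NC(C)=C4C(C)=O)c3)nn2)CC1`, gives 31600 nM.
compound 2, `C=C(C)[C@@H]1CC=C(Cn2cc(COc3cc(C4NC(=O)NC(C)=C4C(C)=O)ccc3OC)nn2)CC1`, gives only a limit, > 100000 nM.
compound 3, `C=C(C)[C@@H]1CC=C(Cn2cc(COc3ccc(C4NC(=O)NC5=C4C(=O)CC(C)(C)C5)cc3)nn2)CC1`, gives 29900 nM.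

Compound 3 holds the lowest of the two numbers, and compound 1 sits within the scatter of it, so no order is read between the two. For compound 2 the value recorded is a limit of the assay and not a number; this is the limit of > 100000 nM in this assay, at which 1 of the 3 values shown sits. The change from compound 1 to compound 2 is methoxy in place of hydrogen on an aromatic carbon and gives an at least 3.1-fold higher number from compound 1 to compound 2 (0.50 log units; beyond the scatter).

Compound 4, `C=C(C)[C@@H]1CC=C(Cn2cc(COc3ccc(C4NC(=O)NC5=C4C(=O)CC(C)(C)C5)cc3OC)nn2)CC1`, is not yet measured. It differs from compound 3 by methoxy in place of hydrogen on an aromatic carbon. The change from compound 1 to compound 2 and the change from compound 3 to compound 4 are the same kind of change, made twice among these compounds, but on different cores and at a different place: in the first the entering group is ortho to a large group and para to a large group, in the second ortho to a large group and meta to a large group. How the core of compound 3 differs from the core of compound 1 is not broken down here.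

For compound 4 in this assay a step of a 2.7-fold higher number from compound 3 to compound 4 (0.43 log units; beyond the scatter) is expected, in the direction of the measured step, because an at least 3.1-fold higher number from compound 1 to compound 2 (0.50 log units; beyond the scatter) on the other core. The different placement of the methoxy and the different core leave this uncertain, and a limit rather than a number is a real possibility. The estimate for compound 4 is 80000 nM, within 30000 nM and 200000 nM.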

Compound 4, concentration for total growth inhibition: 86200 nM
Beside the measured number, compound 4's estimate is 1.1-fold (0.03 log units) below it; low and high end bracket the measured number.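

In this assay, methoxy in place of hydrogen on an aromatic carbon gives a 2.9-fold higher number from compound 3 to compound 4 (0.46 log units; beyond the scatter) and so moves the number the same way as on the core of compound 1: the same change on two cores in this assay, an at least 3.1-fold higher number (0.50 log units; beyond the scatter) from compound 1 to compound 2 and a 2.9-fold higher number (0.46 log units; beyond the scatter) from compound 3 to compound 4; the limit leaves it open whether they differ.
Compound 2 stands at a limit of the assay and not at a number: the limit of > 100000 nM in this assay, at which 1 of the 4 values shown sits.
Across these two pairs the direction of the change carries from one core to the other, but nothing shows that its size carries, and the pairs also differ in placement: the entering group is ortho to a large group and para to a large group in compound 2, and ortho to a large group and meta to a large group in compound 4.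

The compounds shown leave open whether the shift to a higher number belongs to methoxy itself or would also follow a hydroxyl, a fluorine or an amine on the same aromatic carbon. They also leave open what each core does with methoxy placed as on the other core, so the effects of core and placement stay tied together in these two pairs.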